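The source may hold more compounds than are shown below. What is called first, only, known or untested is meant among the compounds shown, and "the series" means these compounds.

Compound 2 `CCn1cc(-c2nc3ccc([N+](=O)[O-])cc3[nH]2)c(=O)c2cc(F)c(N3CCNCC3)cc21`: 1100 nM
Compound 1 `CCn1cc(-c2nc3ccccc3[nH]2)c(=O)c2cc(F)c(N3CCN(C)CC3)cc21`: 36700 nM

In a functional assay on KB cells (Homo sapiens) for cytotoxicity, read by MTT assay, with a stated time of 48 h (on this read-out higher numbers stand for weaker inhibition and lower numbers for stronger inhibition), compound 2 gives 1100 nM, the lower of the two numbers, while compound 1 gives 36700 nM, a gap well beyond the usual scatter. Compound 3 `CCn1cc(-c2nc3ccc([N+](=O)[O-])cc3[nH]2)c(=O)c2cc(F)c(N3CCN(C)CC3)cc21` is not yet measured; it differs from compound 2 by methyl in place of hydrogen on an amine nitrogen in a ring. Among the measured compounds shown here, no comparison between measured compounds isolates this single change, since compound 1 and compound 2 differ at two places. The expected step in this assay is a 1.8-fold higher number from compound 2 to compound 3 (0.26 log units; within the scatter), a modest move toward weaker inhibition. Compound 3 is therefore estimated at 2000 nM, in the range 600 nM to 7000 nM.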

Compound 3, half-maximal inhibitory concentration: 2500 nM
Estimate against measurement, compound 3: 1.3-fold (0.10 log units) below; the measured number falls inside the stated range.
By their numbers in this assay, from the lowest: compound 2; then compound 3; then compound 1.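

In this assay methyl in place of hydrogen on the ring amine nitrogen, piperazin-1-yl to 4-methylpiperazin-1-yl, gives a 2.3-fold higher number from compound 2 to compound 3 (0.36 log units; beyond the scatter) as a small but real cost. Nitro in place of hydrogen on an aromatic carbon gives a 15-fold lower number from compound 1 to compound 3 (1.17 log units; beyond the scatter) with that methyl held constant, so this single change is a much larger step than the methyl change. Nothing measured here explains either step.

On these data alone, whether an ethyl group or a longer chain on that nitrogen would raise the number further remains open. So does whether an amine in place of nitro would give a similar step.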